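A few compounds are considered here, and "the series" means these few. Any claim that something is new, unique, unknown or untested is made for them only; others in the source may bear on it.

Compound 2 `CCCCN(c1nc2c(C(=O)O)cccc2o1)[C@H](C)c1ccc(-c2ccccc2-c2nnn[nH]2)cc1` gives 0.000285 in an ADME assay on the whole organism (plasma, Macaca fascicularis) for protein binding, read by LC-MS, using equilibrium dialysis and cassette dosing, with a stated time of 24 h, at a dose of 1 mg/kg by the oral route (on this read-out lower numbers stand for a smaller free fraction and higher numbers for a larger free fraction), the highest of the three numbers in hand. Compound 3 `CCCCN(c1nc2c(C(=O)O)cccc2o1)[C@H](C)c1ccc(-c2cc(Cl)ccc2-c2nc(=O)o[nH]2)cc1` gives 0.000135 and compound 1 `C[C@H](c1ccc(-c2cc(Cl)ccc2-c2nc(=O)o[nH]2)cc1)N(CC1CC1)c1nc2c(C(=O)O)cccc2o1` gives 0.000108; both gaps to compound 2 lie beyond the scatter. Among the measured compounds shown here, the only single-point step in the set, a 1.3-fold higher number from compound 1 to compound 3 (0.10 log units; within the scatter), concerns the chain on the nitrogen bound to the aromatic ring and sits within the scatter. Compound 4 `CCCCN(c1nc2c(C(=O)NS(C)(=O)=O)cccc2o1)[C@H](C)c1ccc(-c2ccccc2-c2nnn[nH]2)cc1` differs from compound 2 by methanesulfonamido in place of hydroxy on a carbonyl carbon. For the measured compounds named here, no measured step touches the carbonyl carbon, so nothing in this set speaks for a shift beyond the scatter in either direction, and the expected step is a 1.1-fold lower number from compound 2 to compound 4 (0.06 log units; within the scatter). Compound 4 is accordingly estimated at 0.00025, with a range from 0.0001 to 0.0006.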

Compound 4, unbound fraction: 0.00103
Compound 4: the middle estimate sits 4.1-fold (0.61 log units) below what was measured; measured number above the stated range.
By their numbers in this assay, from the lowest: compounds 1 and 3 (each within the scatter of the next); then compound 2; then compound 4.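

In this assay methanesulfonamido in place of hydroxy on a carbonyl carbon gives a 3.6-fold higher number from compound 2 to compound 4 (0.56 log units; beyond the scatter) and so marks this position as one where a single change moves the free fraction beyond the scatter. Among the compounds shown here, the only earlier step, a 1.3-fold higher number from compound 1 to compound 3 (0.10 log units; within the scatter), concerned the chain on the nitrogen and stayed within it. Nothing in hand accounts for the shift.

As far as these compounds go, whether a primary amide or (ethylsulfonyl)carbamoyl on this carbonyl carbon moves the number in the same way remains open. So does whether the same change holds on the background of compound 3.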